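Amide-side ring substitution in the catechol-ether series

A few compounds are considered here, and "the series" means these few. Any claim that something is new, unique, unknown or untested is made for them only; others in the source may bear on it.

Among the measured compounds shown here, in an assay on isolated protein for inhibition of phosphodiesterase 4A (Sus scrofa) (on this read-out higher numbers stand for weaker inhibition and lower numbers for stronger inhibition), compound 3 `COc1ccc(C(=O)Nc2c(F)cccc2Cl)cc1OC1CCCC1` gives 240 nM, the highest number measured so far, though compound 1 `COc1ccc(C(=O)Nc2ccccc2Cl)cc1OC1CCCC1` with 190 nM and compound 2 `COc1ccc(C(=O)Nc2ccccc2Br)cc1OC1CCCC1` with 130 nM both sit within the scatter of it: a 1.3-fold higher number from compound 1 to compound 3 (0.10 log units; within the scatter) and a 1.8-fold higher number from compound 2 to compound 3 (0.27 log units; within the scatter). The halogen exchange a 1.5-fold lower number from compound 1 to compound 2 (0.16 log units; within the scatter) is likewise within the scatter. Compound 4 `COc1ccc(C(=O)Nc2c(C)cccc2Cl)cc1OC1CCCC1` differs from compound 3 by methyl in place of fluoro on an aromatic carbon. For the measured compounds named here, no measured step exchanges fluoro for methyl; the nearest comparisons are the fluoro-for-hydrogen step from compound 1 to compound 3 and the halogen exchange from compound 1 to compound 2, neither of which went beyond the scatter. Going by the values given here, since none of the measured steps at this position has gone beyond the scatter, no step beyond the scatter is expected in this assay for compound 4 either: a 1.1-fold lower number from compound 3 to compound 4 (0.06 log units; within the scatter). Compound 4 is therefore estimated at 210 nM, with a range from 90 nM to 480 nM.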

Compound 4, half-maximal inhibitory concentration: 100 nM
Beside the measured number, compound 4's estimate is 2.1-fold (0.32 log units) above it; low and high end bracket the measured number.
By their numbers in this assay, from the lowest: compounds 4, 2, 1 and 3 (each within the scatter of the next, the first and the last beyond it).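

In this assay, among the compounds shown here, this position gives its first step beyond the scatter (a 2.4-fold lower number from compound 3 to compound 4 (0.38 log units; beyond the scatter)), modest in size, for methyl in place of fluoro on an aromatic carbon ortho to a large group, so the choice of group here can move the number, which the earlier steps did not show. The separation is limited to this pair, since methyl in place of hydrogen (a 1.9-fold lower number from compound 1 to compound 4 (0.28 log units; within the scatter)) and 2-chloro-6-methylphenyl in place of 2-bromophenyl (a 1.3-fold lower number from compound 2 to compound 4 (0.11 log units; within the scatter)) both stay within the scatter. No available evidence bears on what lies behind the methyl-for-fluoro step.

Open, going by these compounds, is whether an ethyl, a methoxy or an amino group at this position would follow methyl or fluoro. Also open, on these data alone, is how methyl behaves on a ring without the chloro group.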